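This account rests on a few compounds, and the source may have more. Where it says the series, first, only, none or still open, it means among the compounds named here.

The shared core of these compounds carries an aryl group on an amine nitrogen in a ring. Compound 1 `Cc1ccc(N2CCN(Cn3nc(-c4ccc5c(c4)OCCO5)oc3=S)CC2)c(C)c1` bears 2,4-dimethylphenyl there; in a functional assay on BGC-823 cells (Homo sapiens) for antiproliferative activity, read by MTT assay, with a stated time of 48 h (on this read-out lower numbers stand for stronger inhibition and higher numbers for weaker inhibition), compound 1 gives 28300 nM. Compound 2 `Fc1ccccc1N1CCN(Cn2nc(-c3ccc4c(c3)OCCO4)oc2=S)CC1` carries 2-fluorophenyl in its place. In this assay compound 2 gives only a limit, > 50000 nM, so its position is known solely as that limit. Compound 3 `S=c1oc(-c2ccc3c(c2)OCCO3)nn1CN1CCN(c2ccccc2Cl)CC1` carries 2-chlorophenyl. In this assay compound 3 likewise gives a limit, > 50000 nM. The changes at this position gave an at least 1.7-fold higher number from compound 1 to compound 2 (0.24 log units; that floor lies within the scatter) and an at least 1.7-fold higher number from compound 1 to compound 3 (0.24 log units; that floor lies within the scatter), while between the two halogen compounds there is a step that the two limits leave unreadable from compound 2 to compound 3. Two of the three values sit at the limit of > 50000 nM in this assay, at which 2 of the 3 values shown sit, which sets the floor for what can be read here. Compound 4 `S=c1oc(-c2ccc3c(c2)OCCO3)nn1CN1CCN(c2ccccn2)CC1` differs from compound 2 by pyridin-2-yl in place of 2-fluorophenyl on an amine nitrogen in a ring. Among the compounds with values here, both aryl replacements at this position ended at the same limit, and no measured step points toward a gain. The expectation for compound 4 in this assay is accordingly a number near that limit, 40000 nM, with a range from 12000 nM to 120000 nM. That expected outcome amounts to an at least 1.2-fold lower number from compound 2 to compound 4 (0.09 log units; that floor lies within the scatter).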

Compound 4, half-maximal inhibitory concentration: 25900 nM
Beside the measured number, compound 4's estimate is 1.5-fold (0.19 log units) above it; the measured number falls inside the stated range.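

Compound 4 shows that a group other than 2,4-dimethylphenyl can give a measured number rather than a limit at this position in this assay, and that this group can be pyridin-2-yl, which carries a ring nitrogen. Pyridin-2-yl gives an at least 1.9-fold lower number from compound 2 to compound 4 (0.28 log units; that floor lies within the scatter) and an at least 1.9-fold lower number from compound 3 to compound 4 (0.28 log units; that floor lies within the scatter), while the comparison with the 2,4-dimethylphenyl group gives a 1.1-fold lower number from compound 1 to compound 4 (0.04 log units; within the scatter), so compound 1 and compound 4 cannot be told apart. The step from compound 2 to compound 3 cannot be read, and the true size of the two floors stays unknown, because these halogen compounds give only limits: the limit of > 50000 nM in this assay, at which 2 of the 4 values shown sit.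

The compounds shown leave open whether an unsubstituted phenyl, a pyrimidin-2-yl or a methoxyphenyl group at this position would move the number beyond the scatter. They also leave open whether any aryl group here can give much stronger inhibition than compound 1 and compound 4.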